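A Ring Swap on the Aromatic Nitrogen

The source may hold more compounds than are shown below. What is called first, only, known or untested is meant among the compounds shown, and "the series" means these compounds.

Compound 1 `O=c1c(S(=O)(=O)c2ccc(F)cc2F)cc2cnc(Nc3ccc4[nH]ccc4c3)nc2n1C1CCCC1`: 5000 nM
Compound 2 `O=c1c(S(=O)(=O)c2ccc(F)cc2F)cc2cnc(Nc3ccc4[nH]ccc4c3)nc2n1CC1CCCC1`: 7000 nM

Of the compounds shown here, two have been measured in a functional assay on K562 cells (Homo sapiens) for inhibition, read by trypan blue exclusion, with a stated time of 72 h; on this read-out higher numbers stand for weaker inhibition and lower numbers for stronger inhibition. Compound 1 gives 5000 nM in this assay, and compound 2 gives 7000 nM. Compound 2 stands at the top of the two numbers shown, yet the step of a 1.4-fold higher number from compound 1 to compound 2 (0.15 log units; within the scatter) is within the scatter, so the two cannot be told apart. Compound 3 `O=c1c(S(=O)(=O)c2ccc(F)cc2F)cc2cnc(Nc3ccc4[nH]ccc4c3)nc2n1C1CCCCC1` differs from compound 2 by cyclohexyl in place of cyclopentylmethyl on an aromatic nitrogen. Among the compounds with values here, the only measured step, a 1.4-fold higher number from compound 1 to compound 2 (0.15 log units; within the scatter), concerns the same aromatic nitrogen and shows nothing beyond the scatter; no step to cyclohexyl has been measured. The step of a 1.3-fold lower number from compound 2 to compound 3 (0.10 log units; within the scatter) is therefore expected to remain within the scatter. The estimate for compound 3 is 5500 nM, with a range from 2000 nM to 15000 nM.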

Compound 3, half-maximal inhibitory concentration: 10000 nM
Compound 3: the middle estimate sits 1.8-fold (0.26 log units) below what was measured; low and high end bracket the measured number.
By their numbers in this assay, from the lowest: compounds 1, 2 and 3 (each within the scatter of the next).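

In this assay, cyclohexyl in place of cyclopentylmethyl gives a 1.4-fold higher number from compound 2 to compound 3 (0.15 log units; within the scatter) and cyclohexyl in place of cyclopentyl gives a 2.0-fold higher number from compound 1 to compound 3 (0.30 log units; within the scatter) on the same aromatic nitrogen. A six-membered non-aromatic ring at this position therefore cannot be told apart from either group with a five-membered ring. Nothing available bears on this result.

The compounds shown leave open whether an amine or a carboxylic acid on this nitrogen would move the number beyond the scatter. They also leave open how the (2,4-difluorophenyl)sulfonyl group, shared by all three, contributes.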